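The source may report more compounds than this note shows. Statements on the series, on what has been measured and on what is new or still open speak of the compounds shown alone.

Among the compounds with values here, compound 1 `CS/C(=N\C(=O)c1ccno1)NC(=O)c1ccno1` is one of two compounds measured in an ADME assay on MCF-10A cells (Homo sapiens) for cytotoxicity, read by MTT assay, with a stated time of 72 h; on this read-out higher numbers stand for weaker inhibition of growth and lower numbers for stronger inhibition of growth. In this assay compound 1 gives 16900 nM, the higher of the two numbers on hand. Its nearest neighbour, compound 2 `CS/C(=N\C(=O)c1ccco1)NC(=O)c1ccco1`, gives 8220 nM in this assay, and the gap between these two lies beyond the usual scatter of repeated measurements. Compounds 1 and 2 differ in both rings at once, so no single-point comparison between them is available.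

Compound 3 `C[Se]/C(=N\C(=O)c1ccno1)NC(=O)c1ccno1` has not yet been measured. It differs from compound 1 in one place: a group of 2 heavy atoms (1 carbon, 1 selenium; no ring) in place of a group of 2 heavy atoms (1 carbon, 1 sulfur; no ring), on a carbon with a double bond to nitrogen. A swap of sulfur for selenium within a group of the same size, away from either ring, is a small change in the shape of the molecule. Within the data shown here, nothing among the measured compounds shows what such a swap does here, so the step is expected to be small in this assay, in no clear direction and not beyond the scatter. On that basis compound 3 is expected to give about 15000 nM in this assay, within a range from 6000 nM to 40000 nM. The step this estimate means is a 1.1-fold lower number from compound 1 to compound 3 (0.05 log units; within the scatter).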

Compound 3, concentration for 50% growth inhibition: 2890 nM
Compound 3: middle estimate off by 5.2-fold (0.72 log units), on the high side; measured number outside the range, below it.
By their numbers in this assay, from the lowest: compound 3; then compound 2; then compound 1.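

In this assay, exchanging the sulfur of the methylsulfanyl group for selenium gives a 5.8-fold lower number from compound 1 to compound 3 (0.77 log units; beyond the scatter), a step beyond the usual scatter and towards stronger inhibition of growth. This shows that the group on a carbon with a double bond to nitrogen matters in this read-out: one changed atom, in a group of the same size, is enough to move the number clearly, which compound 1 and compound 2 could not show because they differ in both rings at once. No measurement on hand explains why this exchange has such an effect, so its cause stays unknown.

As far as these compounds go, it remains open whether the same exchange would move the number by a similar amount when made on compound 2, with its different rings, since a single pair cannot show whether the step holds beyond the core of compound 1. From the compounds shown here alone, it is also open how this place would respond to a different group, such as an amine or a longer chain like ethylselanyl, in place of the methylsulfanyl group.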